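Hydroxy for methoxy on the urea-linked pyrazole series

The source may hold more compounds than are shown below. What is called first, only, known or untested is meant among the compounds shown, and "the series" means these compounds.

Compound 3 `COc1cc(-c2nn(-c3cccc(NC(=O)Nc4ccc(Cl)c(C(F)(F)F)c4)c3)cc2-c2ccncc2)ccc1Cl`: 837 nM
Compound 2 `O=C(Nc1cccc(-n2cc(-c3ccncc3)c(-c3ccc(Cl)c(O)c3)n2)c1)Nc1ccc(Cl)c(Cl)c1`: 940 nM
Compound 1 `O=C(Nc1cccc(-n2cc(-c3ccncc3)c(-c3ccc(Cl)c(O)c3)n2)c1)Nc1cccc(C(F)(F)F)c1`: 2240 nM

Of the compounds shown here, three sharing one core have been tested in a functional assay on A498 cells (Homo sapiens) for inhibition, read by sulforhodamine B assay, with a stated time of 48 h; a lower number here means a stronger inhibitor of growth, a higher number a weaker inhibitor of growth. Compound 3 gives the lowest number of the three, but compound 2 sits so close to it that the two cannot be told apart; only compound 1 stands clearly higher. For the measured compounds named here, the one measured step, a 2.4-fold lower number from compound 1 to compound 2 (0.38 log units; beyond the scatter), concerns the aryl group on the urea and says nothing about the other end of the molecule.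

Compound 4 `O=C(Nc1cccc(-n2cc(-c3ccncc3)c(-c3ccc(Cl)c(O)c3)n2)c1)Nc1ccc(Cl)c(C(F)(F)F)c1` differs from compound 3 in a single place: hydrogen in place of methyl on an oxygen on an aromatic ring. Going by the values given here, no measured pair isolates this change. Compounds 1 and 2 both carry the hydroxy group, yet each also carries a different urea aryl than compound 3, so the effect of the methyl alone cannot be read from them. Among the compounds with values here, what can be said is that every compound so far, hydroxy or methoxy, lands in the same broad region of this assay.

The expectation for compound 4 is therefore a small step, a 1.1-fold higher number from compound 3 to compound 4 (0.03 log units; within the scatter), most likely within the scatter. Compound 4 is estimated at 900 nM, with a range from 400 nM to 2000 nM.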

Compound 4, concentration for 50% growth inhibition: 1400 nM
Estimate against measurement, compound 4: 1.6-fold (0.19 log units) below, and the stated range covers the measured number.
By their numbers in this assay, from the lowest: compounds 3, 2, 4 and 1 (each within the scatter of the next, the first and the last beyond it).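

In this assay, for the compounds shown here, the change from methoxy to hydroxy on the 4-chloro-3-methoxyphenyl group can now be read directly for the first time, and it gives a 1.7-fold higher number from compound 3 to compound 4 (0.22 log units; within the scatter), so the two groups cannot be told apart at this oxygen. Compound 4 also connects the urea aryl groups: trifluoromethyl in place of chloro gives a 1.5-fold higher number from compound 2 to compound 4 (0.17 log units; within the scatter) and chloro in place of hydrogen gives a 1.6-fold lower number from compound 1 to compound 4 (0.20 log units; within the scatter), so neither step can be separated from the scatter, even though the earlier step, a 2.4-fold lower number from compound 1 to compound 2 (0.38 log units; beyond the scatter), lies beyond it. No outside measurement on these compounds is available to explain these small differences.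

From the compounds shown here alone, the methoxy-to-hydroxy comparison rests on one matched pair, with a single urea aryl group, so it remains open whether the same small step would appear with the aryl groups of compound 1 or compound 2. Going by these compounds, it also remains open whether a longer group on this oxygen, such as ethoxy, or an amine in place of the hydroxy group would stay in the same range in this assay.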